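Fluoro for chloro on the shared amide core

This account rests on a few compounds, and the source may have more. Where it says the series, first, only, none or still open, it means among the compounds named here.

Measured so far, in a functional assay on the whole organism (integument) for inhibition, with Chilo suppressalis as the target, read by scintillation counting, with a stated time of 72 h; a lower number here means a stronger inhibitor, a higher number a weaker inhibitor:
- compound 1, `O=C(Nc1nnc(-c2ccc(Cl)cc2)s1)c1ccccc1`, gives > 5010 nM; this is a limit of the assay, not a number.
- compound 2, `COc1cccc(OC)c1C(=O)Nc1nnc(-c2ccc(Cl)cc2)s1`, gives 58.9 nM.
- compound 3, `COc1ccccc1C(=O)Nc1nnc(-c2ccc(Cl)cc2)s1`, gives 53.7 nM.

Among the two plain numbers, compound 2 stands highest, with compound 3 nearest: a 1.1-fold lower number from compound 2 to compound 3 (0.04 log units; within the scatter), so the two cannot be told apart. The value of compound 1 is a limit, as the limit of > 5010 nM in this assay, at which 1 of the 3 values shown sits, records, and from it the step of an at least 93-fold lower number from compound 1 to compound 3 (1.96 log units; beyond the scatter) is large. Both measured steps concern a methoxy on the ring that carries the carbonyl.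

Compound 4, `COc1cccc(OC)c1C(=O)Nc1nnc(-c2ccc(F)cc2)s1`, differs from compound 2 elsewhere: fluoro in place of chloro on an aromatic carbon. For the measured compounds named here, no measured step touches this ring or this position, so the measured steps give no direct guide. What they do show is that the shared core of compound 2 and compound 3 holds its value when the other ring is altered in a small way. On that ground, the change from compound 2 to compound 4 is expected to give a step of no more than the usual scatter in this assay, in either direction: a 1.0-fold higher number from compound 2 to compound 4 (0.01 log units; within the scatter). Compound 4 is therefore estimated at 60 nM, likely between 20 nM and 180 nM.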

Compound 4, half-maximal inhibitory concentration: 97.7 nM
Compound 4: the middle estimate sits 1.6-fold (0.21 log units) below what was measured; the range from low to high includes it.
By their numbers in this assay, from the lowest: compounds 3, 2 and 4 (each within the scatter of the next). At a limit, above all of these: compound 1.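

Moving from 4-chlorophenyl to 4-fluorophenyl touches a ring that no earlier step had changed, and in this assay it gives a 1.7-fold higher number from compound 2 to compound 4 (0.22 log units; within the scatter). The two compounds therefore cannot be told apart, which shows that, in this one pair, chloro is not required at this position: fluoro, a different halogen, serves in its place with no change that the assay can resolve. The data at hand offer no explanation of this step, and a step within the scatter gives little to explain.

A single pair of halogens says little about how much freedom this position has in general, so what a methyl, a trifluoromethyl, a methoxy or an amine would do at the same place remains an open question. For the compounds shown here, it is also open whether the exchange of chloro for fluoro would read the same on the core of compound 3, since so far it has been seen only on the core of compound 2, and a second pair would show whether the result carries over.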